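From methoxy to hydroxy on an aromatic ring

This account rests on a few compounds, and the source may have more. Where it says the series, first, only, none or still open, it means among the compounds named here.

Values in a functional assay on MGC-803 cells (Homo sapiens) for inhibition, read by MTT assay, with a stated time of 72 h (a lower number here means a stronger inhibitor, a higher number a weaker inhibitor), are:
Compound 1 `C#CCSc1nc(NCCC(C)C)c2ccncc2n1` gives > 80000 nM as a limit, not a number
Compound 2 `C#CCSc1nc(Nc2cccc(Cl)c2)c2ccncc2n1` gives 2190 nM
Compound 3 `C#CCSc1nc(Nc2cccc(OC)c2)c2ccncc2n1` gives 2070 nM

Compound 3 sits level with compound 2 within the scatter. Compound 4 `C#CCSc1nc(Nc2cccc(O)c2)c2ccncc2n1` differs from compound 3 by hydrogen in place of methyl on an oxygen on an aromatic ring in one place: hydrogen in place of methyl on an oxygen on an aromatic ring, turning methoxy to hydroxy. The nearest guide is a swap of methoxy in place of chloro on an aromatic carbon, which gave a 1.1-fold lower number from compound 2 to compound 3 (0.02 log units; within the scatter) in this assay and so stayed within the scatter. The other step, an at least 36-fold lower number from compound 1 to compound 2 (1.56 log units; beyond the scatter) on swapping isopentyl for 3-chlorophenyl on a nitrogen, was large but concerns a different place. Within the data shown here, no measured step touches that oxygen, so only a slightly higher number is expected, with nothing beyond the scatter: the estimate is a 1.2-fold higher number from compound 3 to compound 4 (0.08 log units; within the scatter) and no more. For compound 4 the expected value in this assay is 2500 nM with a range from 900 nM to 7000 nM as the estimate.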

Compound 4, half-maximal inhibitory concentration: 15700 nM
Compound 4: the middle estimate sits 6.3-fold (0.80 log units) below what was measured, outside the stated range (above it).
By their numbers in this assay, from the lowest: compounds 3 and 2 (each within the scatter of the next); then compound 4. At a limit, above all of these: compound 1.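

In this assay, the oxygen on the aromatic ring proves sensitive to a very small change, since losing one methyl gives a 7.6-fold higher number from compound 3 to compound 4 (0.88 log units; beyond the scatter) and so separates hydroxy from methoxy. Chloro and methoxy stood level, yet hydroxy does not join them, with a 7.2-fold higher number from compound 2 to compound 4 (0.86 log units; beyond the scatter) on that swap. Compound 4 still improves on the isopentyl compound, but an at least 5.0-fold lower number from compound 1 to compound 4 (0.70 log units; beyond the scatter) is only a bound, as compound 1 stands at a limit: the limit of > 80000 nM in this assay, at which 1 of the 4 values shown sits.

From the compounds shown here alone, whether an amine or a carboxylic acid on that aromatic carbon would stand with chloro and methoxy or with hydroxy remains open. So does whether ethoxy would match methoxy.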